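The source may hold more compounds than are shown below. What is called first, only, known or untested is meant among the compounds shown, and "the series" means these compounds.

Working notes on the oxalanilide and aryloxyacetamide series bearing a fluorophenoxyacetic acid.

Compound 1 `O=C(O)COc1ccc(NC(=O)C(=O)Nc2ccccc2)cc1F` is the reference. In a functional assay on CHO cells for agonist activity at Free fatty acid receptor 1 (Homo sapiens), read by FLIPR, tested at 100 nM (a lower number here means a weaker effect, a higher number a stronger effect of the compound at the concentration tested), compound 1 gives 9.78%. Compound 2 `Cc1cccc(NC(=O)C(=O)Nc2ccc(OCC(=O)O)c(F)c2)c1` carries the same core with one change, (methyl in place of hydrogen on an aromatic carbon), and in this assay compound 2 gives 17.7%. The step is a number 7.9 percentage points higher from compound 1 to compound 2 (within the scatter), so the two values cannot be ordered.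

Compound 3 `CC(C)c1cccc(OCC(=O)Nc2ccc(OCC(=O)O)c(F)c2)c1` has a different core; the difference between the two cores is not broken down here. In this assay compound 3 gives 43.3%, the highest of the three numbers, with the gaps to compound 2 and to compound 1 both beyond the scatter.

Compound 4 `Cc1ccc(C(C)C)cc1OCC(=O)Nc1ccc(OCC(=O)O)c(F)c1` has not been measured. It differs from compound 3 by methyl in place of hydrogen on an aromatic carbon. This is the same kind of change as that from compound 1 to compound 2, though not the same: in the earlier pair the methyl enters meta to a large group, whereas in compound 4 it enters ortho to a large group and para to an isopropyl group. Among the compounds shown the change occurs twice in all, with only one measured instance.

Resting on the small step of a number 7.9 percentage points higher from compound 1 to compound 2 (within the scatter), the expected step from compound 3 to compound 4 in this assay is a number 4.7 percentage points higher from compound 3 to compound 4 (within the scatter), which would stay within the scatter. The estimate for compound 4 in this assay is therefore 48%, expected between 30% and 66%.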

Compound 4, a percentage reported as activity, at one concentration (the size of the read-out at that concentration, not a potency): 14.6%
Compound 4: middle estimate off by 33.4 percentage points, on the high side, and the stated range ends above it.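

The methyl in place of hydrogen on an aromatic carbon, here ortho to a large group and para to an isopropyl group, gives a number 28.7 percentage points lower from compound 3 to compound 4 (beyond the scatter) in this assay, so this small change is enough to remove most of the read-out seen for compound 3 at the concentration tested. Set beside the earlier instance, the change does not behave as one transferable step from the core of compound 1 to the core of compound 3: the same change on two cores in this assay, a number 7.9 percentage points higher (within the scatter) from compound 1 to compound 2 and a number 28.7 percentage points lower (beyond the scatter) from compound 3 to compound 4, 36.6 percentage points apart, beyond the scatter of two such steps. This does not show which difference matters, since the two pairs differ both in the core and in where the methyl sits, and two instances at a single concentration support no general rule about potency or about the methyl on other cores in this series.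

The compounds shown leave open whether the loss belongs to the methyl itself or to the carbon it occupies, which the same methyl at another carbon of that ring of compound 3 would help to separate. Also open, on these data alone, is whether a chloro group, a methoxy group or a longer chain such as ethyl at the carbon used in compound 4 would give a read-out closer to that of compound 3 or to that of compound 4.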